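Removing one bromo group from compound 3

This account rests on a few compounds, and the source may have more. Where it says the series, first, only, none or still open, it means among the compounds named here.

The set holds compound 1 `Oc1cc(Br)c(Cc2ccc(O)c(Br)c2)cc1O`, compound 2 `O=C(c1cc(Br)ccc1O)c1cc(O)c(O)cc1Br`, compound 3 `Oc1cc(Cc2ccccc2)c(Br)c(Br)c1O` and the not yet measured compound 4 `Oc1cc(Br)c(Cc2ccccc2)cc1O`. In a functional assay on HUVEC cells (Homo sapiens) (a lower number here means that less compound is needed, a higher number that more compound is needed for the effect), compound 1 gives 13000 nM, compound 2 gives 400 nM and compound 3 gives 3900 nM. Compound 3 thus stands second highest of the three numbers: compound 1 lies above it by a margin beyond the scatter, and compound 2 lies below it by a wider margin, also beyond the scatter. Compound 4 differs from compound 3 in one place: hydrogen in place of bromo on an aromatic carbon. Among the compounds with values here, no measured pair in the set isolates this change, so its size is open. A modest step toward a higher number is expected, a 1.5-fold higher number from compound 3 to compound 4 (0.19 log units; within the scatter). For compound 4 in this assay the estimate is 6000 nM, within 1500 nM to 25000 nM.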

Compound 4, half-maximal effective concentration: 12200 nM
Estimate against measurement, compound 4: 2.0-fold (0.31 log units) below, within the range that was stated.
By their numbers in this assay, from the lowest: compound 2; then compound 3; then compounds 4 and 1 (each within the scatter of the next).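

In this assay, within the data shown here, hydrogen in place of the bromo group that is ortho to a bromo group and ortho to a hydroxy group gives a 3.1-fold higher number from compound 3 to compound 4 (0.50 log units; beyond the scatter) and thus isolates this single position for the first time. Losing this one bromo group therefore registers beyond the scatter, which no earlier comparison could show. Nothing available explains the size of this step.

As far as these compounds go, whether a chloro, methoxy or amino group at this carbon would sit nearer compound 3 or compound 4 remains open. Also open, from the compounds shown here alone, is whether the step persists with other groups on the second aromatic ring.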